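The compounds below may be only part of what the source reports. "The series", "measured", "known", "first", "only" and "open" are said of these compounds alone.

Compound 1 `CCNC(=O)C1=C(C)NC(=O)NC1c1cccs1` and compound 2 `CCNC(=O)C1=C(C)NC(=O)NC1c1ccsc1` share a core and differ only in the heteroaryl group on a saturated ring carbon. In an assay on membranes from HEK293 cells for displacement of a labelled ligand from adenosine receptor A2b (Homo sapiens), read by scintillation counting, with a stated time of 30 min, tested at 1 uM (on this read-out lower numbers stand for less inhibition and higher numbers for more inhibition at the one concentration tested (going by the name of the read-out)), compound 1 gives 1%, and in this assay compound 2 gives 1%. The step of no change at the digits printed from compound 1 to compound 2 (within the scatter) lies within the scatter, so compound 2 stands level with compound 1, both at the lower end of what this read-out can report.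

Compound 3 `CCSC(=O)C1=C(C)NC(=O)NC1c1ccsc1` keeps the core and heteroaryl group of compound 2 and differs from it in one place: ethylsulfanyl in place of ethylamino on a carbonyl carbon. Among the measured compounds shown here, no measured step bears on this change; the only step on record, thiophen-3-yl in place of thiophen-2-yl, concerns a different part of the molecule and was within the scatter. For the measured compounds named here, the change in compound 3 therefore has no measured precedent here, and the expectation rests on where compound 2 stands. Compound 3 is expected to give about 3%, within a range from 0% to 15%. The expected step of a number 2 percentage points higher from compound 2 to compound 3 (within the scatter) is estimated to stay within the scatter, in no clear direction.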

Compound 3, a percentage reported as inhibition, at one concentration (the size of the read-out at that concentration, not a potency): 17%
Estimate against measurement, compound 3: 14 percentage points below; measured number outside the range, above it.
By their numbers in this assay, from the lowest: compounds 1 and 2 (each within the scatter of the next); then compound 3.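

In this assay, among the compounds shown here, the substituent on the carbonyl carbon is the first place where a single change gives a step beyond the scatter: a number 16 percentage points higher from compound 2 to compound 3 (beyond the scatter), a modest step on replacing ethylamino with ethylsulfanyl. This position therefore responds to substitution, whereas the exchange of thiophen-2-yl for thiophen-3-yl gave no change at the digits printed from compound 1 to compound 2 (within the scatter), and the response appears even though both groups have 3 heavy atoms and neither contains a ring. No measurement available here explains why the thioester-type compound 3 reads higher than compound 2.

The compounds shown leave open whether the step follows from the sulfur itself or from the loss of the ethylamino nitrogen and its hydrogen, a question that a compound carrying ethoxy at this position could help to separate. They also leave open whether a longer chain such as propylsulfanyl would carry the number further, and whether ethylsulfanyl would give a similar step with thiophen-2-yl on the saturated ring carbon.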